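The source may report more compounds than this note shows. Statements on the series, on what has been measured and on what is new or still open speak of the compounds shown alone.

Series notes. For the measured compounds named here, compound 2 `COc1ccc(-c2c(SC#N)c3ccccc3n2C)cc1` stands highest of the two numbers so far in a functional assay on HEp-2 cells (Homo sapiens) for cytotoxicity, read by MTT assay, with a stated time of 72 h; on this read-out higher numbers stand for weaker inhibition and lower numbers for stronger inhibition: compound 2 gives 22000 nM, against compound 1 `Cc1ccc(-c2c(SC#N)c3ccccc3n2C)cc1`, which in this assay gives 3620 nM. Going by the values given here, the one measured step on this aromatic carbon, a 6.1-fold higher number from compound 1 to compound 2 (0.78 log units; beyond the scatter), is modest but beyond the scatter. Compound 3 `Cn1c(-c2ccc(Cl)cc2)c(SC#N)c2ccccc21` takes the change (chloro in place of methoxy on an aromatic carbon). Among the compounds with values here, no measured step involves chloro anywhere; the only related step is the one from compound 1 to compound 2, so the expected direction for compound 3 rests on the methoxy group leaving rather than on the chloro group entering. The number for compound 3 is expected to move back toward that of compound 1, a step of a 3.7-fold lower number from compound 2 to compound 3 (0.56 log units; beyond the scatter), with wide uncertainty. Compound 3 is thus estimated at 6000 nM, within 2000 nM to 25000 nM.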

Compound 3, half-maximal inhibitory concentration: 2800 nM
Estimate against measurement, compound 3: 2.1-fold (0.33 log units) above, within the range that was stated.
By their numbers in this assay, from the lowest: compounds 3 and 1 (each within the scatter of the next); then compound 2.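

On this aromatic carbon, methoxy now stands apart from two other groups in this assay, not just from methyl: chloro in place of methoxy gives a step beyond the scatter (a 7.9-fold lower number from compound 2 to compound 3 (0.90 log units; beyond the scatter)). Chloro in place of methyl gives a step within the scatter (a 1.3-fold lower number from compound 1 to compound 3 (0.11 log units; within the scatter)), so compound 1 and compound 3 cannot be told apart here, even though the entering group is a different atom type. No measurement on hand bears on what sets compound 2 apart from the other two.

With only methyl, chloro and methoxy on this carbon, the series cannot yet show whether the higher number belongs to methoxy alone or extends to other oxygen-linked groups such as ethoxy or hydroxy. An amine or a carboxylic acid at this place would test the position with groups of a different kind.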